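This account rests on a few compounds, and the source may have more. Where it says the series, first, only, none or still open, it means among the compounds named here.

Measured so far:
compound 1, `C=CCn1c(=O)/c(=C\c2cccc(F)c2)[nH]c(=O)/c1=C\c1ccccc1OC` — 5600 nM
compound 2, `C=CCn1c(=O)/c(=C\c2ccccc2Cl)[nH]c(=O)/c1=C\c1ccccc1OC` — 4600 nM
compound 3, `C=CCn1c(=O)/c(=C\c2cc(Br)ccc2F)[nH]c(=O)/c1=C\c1ccccc1OC` — "not active" (no number reported)

Within the data shown here, compound 2 has the lowest of the two numbers in a functional assay on BGC-823 cells (Homo sapiens) for cytotoxicity, read by CCK-8 assay, with a stated time of 72 h; a higher number here means a weaker inhibitor, a lower number a stronger inhibitor; its only measured neighbour with a number, compound 1, differs by a 1.2-fold lower number from compound 1 to compound 2 (0.09 log units; within the scatter), so the two stand within the scatter of one another. Compound 3 is recorded as not active in this assay, without a number.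

Compound 4, `C=CCn1c(=O)/c(=C\c2cc(F)ccc2C)[nH]c(=O)/c1=C\c1ccccc1OC`, is the next compound, reached from compound 2 by 5-fluoro-2-methylphenyl in place of 2-chlorophenyl on a double-bonded chain carbon bound to an aromatic carbon.

Among the measured compounds shown here, no measured step changes the same part of the molecule in the same way, so the only guidance comes from the values of compound 1 and compound 2, which lie within the scatter of each other, and from compound 3, the one other disubstituted phenyl in the set, which was not active. Given that, he expects compound 4 to show a step of a 1.4-fold higher number from compound 2 to compound 4 (0.15 log units; within the scatter), which is not beyond the scatter, with some risk of a weaker outcome. His estimate for compound 4 in this assay is 6500 nM, within a range of 2500 nM to 20000 nM.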

Compound 4, half-maximal inhibitory concentration: 1600 nM
Estimate against measurement, compound 4: 4.1-fold (0.61 log units) above, and the stated range ends above it.
By their numbers in this assay, from the lowest: compound 4; then compounds 2 and 1 (each within the scatter of the next).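

The aromatic group on the double-bonded chain carbon can move the number beyond the scatter in this assay: the earlier step at this place stayed within the scatter, whereas this change gives a 2.9-fold lower number from compound 2 to compound 4 (0.46 log units; beyond the scatter). The clearest single change is methyl in place of hydrogen on an aromatic carbon, which gives a 3.5-fold lower number from compound 1 to compound 4 (0.54 log units; beyond the scatter), so adding this one group to the fluorophenyl of compound 1 is enough for a step beyond the scatter. Nothing available explains this gain.

The compounds shown leave open whether the methyl would give a similar step on a phenyl without the fluorine, and whether a longer chain such as ethyl could take its place. They also do not show how an amine or a carboxylic acid on this aromatic ring would read in this assay.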